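A Methyl on the Sulfonamide Nitrogen of Compound 2

This account rests on a few compounds, and the source may have more. Where it says the series, first, only, none or still open, it means among the compounds named here.

In a physicochemical assay for solubility, in phosphate buffer, measured as kinetic solubility, at pH 7.4, tested at 250 uM (on this read-out lower numbers stand for lower solubility and higher numbers for higher solubility), compound 1 (`CCCCCCNc1ccc(C(=O)O)cc1S(=O)(=O)NC`) reads 247000 nM and compound 2 (`CCCCCCCCNc1ccc(C(=O)O)cc1S(=O)(=O)NC`) reads 53000 nM on the same scale, which leaves compound 2 with the lower of the two numbers. Compound 3 (`CCCCCCCCNc1ccc(C(=O)O)cc1S(=O)(=O)N(C)C`) differs from compound 2 by methyl in place of hydrogen on a sulfonamide nitrogen. For the measured compounds named here, only one measured step is available, and it lies elsewhere in the molecule: a 4.7-fold lower number from compound 1 to compound 2 (0.67 log units; beyond the scatter) with ethyl in place of hydrogen on a saturated chain carbon. Going by the values given here, no measured pair tests a change on the sulfonamide nitrogen, so that step serves only as a guide to size. The added group here is a single methyl, so a smaller step than that one is expected in this assay with a slight lean downward, and it may well stay within the scatter. The estimated change is a 1.5-fold lower number from compound 2 to compound 3 (0.18 log units; within the scatter) and nothing larger is expected. Compound 3 is expected to read about 35000 nM with an estimated range from 10000 nM to 110000 nM when it is measured.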

Compound 3, solubility: 52000 nM
Compound 3: the middle estimate sits 1.5-fold (0.17 log units) below what was measured; measured number inside the range.
By their numbers in this assay, from the lowest: compounds 3 and 2 (each within the scatter of the next); then compound 1.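

For the compounds shown here, at the sulfonamide nitrogen, the only reading so far comes from methyl in place of hydrogen, which gives a 1.0-fold lower number from compound 2 to compound 3 (0.01 log units; within the scatter) in this assay and leaves the two compounds indistinguishable on this scale. The earlier step, a 4.7-fold lower number from compound 1 to compound 2 (0.67 log units; beyond the scatter), lay on the saturated chain and fell beyond the scatter, so the pair now shows that, in the presence of the chain of compound 2, the methylsulfamoyl to dimethylsulfamoyl swap does not separate the readings as that chain step did, a statement resting on this single pair alone. Nothing available here bears on why the reading stays where it does.

From the compounds shown here alone, whether the same swap would also leave the reading in place on the shorter chain of compound 1, where the number stands much higher at 247000 nM in this assay, remains open. Also open, going by these compounds, is how the reading would respond to something larger than methyl on this sulfonamide nitrogen, such as an ethyl or a hydroxyethyl group, or to a primary sulfonamide carrying two hydrogens there.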